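Trifluoromethyl ketones on a thiophene core against histone deacetylase 4

The compounds below may be only part of what the source reports. "The series", "measured", "known", "first", "only" and "open" are said of these compounds alone.

Measured compounds:
Compound 1, `O=C(NCc1ccccc1)c1ccc(C(=O)C(F)(F)F)s1`: 243 nM
Compound 2, `O=C(c1ccc(-c2ncc(-c3ccccc3)s2)s1)C(F)(F)F`: 1500 nM
Compound 3, `O=C(c1ccc(-c2nc(Cc3cccs3)no2)s1)C(F)(F)F`: 15 nM

In an assay for inhibition of histone deacetylase 4 (Homo sapiens) (a higher number here means a weaker inhibitor, a lower number a stronger inhibitor), compound 3 gives the lowest number of the three; its gaps to compound 1 and to compound 2 both lie beyond the scatter, so it stands as the strongest inhibitor here. Compound 4, `O=C(c1ccc(-c2nc(-c3ccc(Cl)cc3Cl)no2)s1)C(F)(F)F`, differs from compound 3 by 2,4-dichlorophenyl in place of (thiophen-2-yl)methyl on an aromatic carbon. Going by the values given here, no step between two measured compounds maps onto this change, so the direction rests on judgement alone. A modest loss seems more likely than a gain, since compound 2, which also carries an aromatic ring attached directly to its five-membered heteroaromatic ring, gives 1500 nM. Compound 4 is therefore expected at 40 nM, within 10 nM to 200 nM, a step of a 2.7-fold higher number from compound 3 to compound 4 (0.43 log units; beyond the scatter) that is estimated, not measured.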

Compound 4, half-maximal inhibitory concentration: 240 nM
The estimate for compound 4 lay 6.0-fold (0.78 log units) below the measured number; measured number outside the range, above it.
By their numbers in this assay, from the lowest: compound 3; then compounds 4 and 1 (each within the scatter of the next); then compound 2.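

In this assay, putting 2,4-dichlorophenyl in place of (thiophen-2-yl)methyl on the aromatic carbon between two ring nitrogen atoms gives a 16-fold higher number from compound 3 to compound 4 (1.20 log units; beyond the scatter). Going by these compounds alone, this single-place step shows that the number depends strongly on the group at this position, which the earlier compounds, differing in more than one place, could not show. Nothing measured here accounts for the size of this step. Still open, from the compounds shown here alone, is whether the rise follows from the ring itself, the two chlorine atoms or the missing carbon link. A plain phenyl, a benzyl group or a morpholine at this carbon could help separate these.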